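Swapping a difluorophenyl for a hydroxyphenyl on the carbonyl

A few compounds are considered here, and "the series" means these few. Any claim that something is new, unique, unknown or untested is made for them only; others in the source may bear on it.

Of the compounds shown here, two have so far been tested in a functional assay on MCF7 cells (Homo sapiens) for cytotoxicity, read by MTT assay, with a stated time of 48 h; on this read-out lower numbers stand for stronger inhibition and higher numbers for weaker inhibition. Compound 1 `COc1cc(-c2nnc3n2NC(c2ccco2)C(C(=O)c2ccccc2)S3)cc(OC)c1OC` gives 39800 nM. Compound 2 `COc1cc(-c2nnc3n2NC(c2ccco2)C(C(=O)c2ccc(F)c(F)c2)S3)cc(OC)c1OC` gives 73200 nM, the higher of the two numbers, yet a 1.8-fold higher number from compound 1 to compound 2 (0.26 log units; within the scatter), so the two cannot really be ranked against each other.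

Compound 3 `COc1cc(-c2nnc3n2NC(c2ccco2)C(C(=O)c2ccc(O)cc2)S3)cc(OC)c1OC` is the next to be measured. It differs from compound 2 in a single place: 4-hydroxyphenyl in place of 3,4-difluorophenyl on a carbonyl carbon. Among the compounds with values here, no measured pair shows this exchange. Within the data shown here, the only step recorded so far, from a phenyl to a 3,4-difluorophenyl on the same carbonyl carbon, was a 1.8-fold higher number from compound 1 to compound 2 (0.26 log units; within the scatter), a change that stayed within the scatter. With nothing pointing in either direction, no step beyond the scatter is expected in this assay for compound 3, and its number is expected to sit near that of compound 2, with a wide range to reflect the lack of a guiding step. Accordingly, the expected step is a 1.3-fold lower number from compound 2 to compound 3 (0.12 log units; within the scatter). Compound 3 is estimated at 55000 nM, with a range from 15000 nM to 180000 nM.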

Compound 3, half-maximal inhibitory concentration: 88900 nM
Compound 3: the middle estimate sits 1.6-fold (0.21 log units) below what was measured; the range from low to high includes it.
By their numbers in this assay, from the lowest: compounds 1, 2 and 3 (each within the scatter of the next, the first and the last beyond it).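

In this assay there is a 1.2-fold higher number from compound 2 to compound 3 (0.08 log units; within the scatter) and this exchange on the carbonyl carbon leaves the two aromatic groups indistinguishable, even though 4-hydroxyphenyl brings a hydrogen-bond donor and a hydrogen-bond acceptor that 3,4-difluorophenyl lacks. Within the data shown here, the pair that adds new information is the one that places hydroxy on the plain phenyl: there is a 2.2-fold higher number from compound 1 to compound 3 (0.35 log units; beyond the scatter) and this is the first step at this position to pass the scatter, a modest weakening of inhibition that shows the position is at least slightly sensitive to what the aromatic ring carries. Why hydroxy has this small effect cannot be said, as no supporting data bear on the result.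

On these data alone, whether the step belongs to hydroxy itself remains open, since a methoxy or an amine in its place could show if a different group gives a similar number. Whether the aromatic ring is needed at all is also unanswered, and a small chain such as methyl on the carbonyl carbon would test that.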